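Fluoro for hydroxy on an aromatic carbon

The source may report more compounds than this note shows. Statements on the series, on what has been measured and on what is new or still open speak of the compounds shown alone.

In a functional assay on HCT-8 cells (Homo sapiens) for cytotoxicity (on this read-out higher numbers stand for an effect only at larger amounts of compound and lower numbers for an effect already at smaller amounts), compound 2 (`Oc1cc(-c2ccccc2)nc2c(O)cccc12`) gives > 10 ug/mL, which is a limit and not a number. Compound 1 (`CCCOc1cc(-c2ccccc2)nc2ccccc12`) gives > 10 ug/mL, also a limit. Compound 3 (`CC(C)COc1cc(-c2ccccc2)nc2ccccc12`) gives > 10 ug/mL, again a limit.

Compound 4 (`Oc1cc(-c2ccccc2)nc2c(F)cccc12`) differs from compound 2 as follows: fluoro in place of hydroxy on an aromatic carbon. Among the measured compounds shown here, the only measured step is a step that the two limits leave unreadable from compound 1 to compound 3, and it concerns a different change, so it offers no size to carry over. Compound 4 is expected to show no step beyond the scatter because of the limit of > 10 ug/mL in this assay, at which 3 of the 3 values shown sit. The expected step is a step that the limit leaves unreadable from compound 2 to compound 4. For compound 4 the estimated value is 15 ug/mL, with an expected range from 6 ug/mL to 40 ug/mL.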

Compound 4, half-maximal effective concentration: 0.04 ug/mL
Compound 4: middle estimate off by 380-fold (2.57 log units), on the high side, and the stated range ends above it.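

In this assay, fluoro in place of hydroxy on this aromatic carbon gives an at least 250-fold lower number from compound 2 to compound 4 (2.39 log units; beyond the scatter). So a change of one heavy atom at this place, ortho to a fused ring, is enough to separate a compound with a readable effect from one without. Among the compounds shown, only compound 4 carries a number rather than a limit: the limit of > 10 ug/mL in this assay, at which 3 of the 4 values shown sit.

Still open, from the compounds shown here alone, is whether the gain comes from losing hydroxy or from gaining fluoro. Chloro, methoxy or an amine on this same carbon would help separate the two.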